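From nitro to chloro on compound 3

The source may report more compounds than this note shows. Statements on the series, on what has been measured and on what is new or still open speak of the compounds shown alone.

- compound 1 `CC1=CC[C@@H]([C@@](C)(O)CCCC(C)(C)NC(=S)NN)CC1`: 49400 nM
- compound 2 `CC1=CC[C@@H]([C@@](C)(O)CCCC(C)(C)NC(=S)N/N=C\c2ccc(N(C)C)cc2)CC1`: 27700 nM
- compound 3 `CC1=CC[C@@H]([C@@](C)(O)CCCC(C)(C)NC(=S)N/N=C\c2cccc([N+](=O)[O-])c2)CC1`: 14100 nM

In a functional assay on HT-29 cells (Homo sapiens) for cytotoxicity, read by sulforhodamine B assay (on this read-out higher numbers stand for weaker inhibition of growth and lower numbers for stronger inhibition of growth), compound 3 gives 14100 nM, a clearly lower number than compound 1 and level with compound 2 within the scatter. The next analogue, compound 4 `CC1=CC[C@@H]([C@@](C)(O)CCCC(C)(C)NC(=S)N/N=C\c2cccc(Cl)c2)CC1`, has not been measured. It differs from compound 3 as follows: chloro in place of nitro on an aromatic carbon. In words, this is chloro in place of nitro on an aromatic carbon. Going by the values given here, only one measured step changes a group on this aromatic ring: a 2.0-fold lower number from compound 2 to compound 3 (0.29 log units; within the scatter). That swap was a larger one and stayed within the scatter, so no step beyond the scatter is expected in this assay. The expected step is a 1.0-fold lower number from compound 3 to compound 4 (0.00 log units; within the scatter). For compound 4 the estimated value is 14000 nM, with an expected range from 7000 nM to 30000 nM.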

Compound 4, concentration for 50% growth inhibition: 6890 nM
For compound 4 the middle estimate is 2.0-fold (0.31 log units) above the measured one; the whole stated range lies above it.
By their numbers in this assay, from the lowest: compound 4; then compounds 3, 2 and 1 (each within the scatter of the next, the first and the last beyond it).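

In this assay, going by these compounds alone, chloro in place of nitro on this aromatic carbon gives a 2.0-fold lower number from compound 3 to compound 4 (0.31 log units; beyond the scatter), the first modest change on this ring to lie beyond the scatter. The 3-chlorophenyl group also gives a 4.0-fold lower number from compound 2 to compound 4 (0.60 log units; beyond the scatter) when it replaces 4-(dimethylamino)phenyl, while the full addition of the chlorine-bearing aromatic group gives a 7.2-fold lower number from compound 1 to compound 4 (0.86 log units; beyond the scatter), also modest. No measurement shown here explains these steps. Still open, going by these compounds, is how a fluoro, a methoxy or a carboxylic acid would fare on this carbon, and whether chloro elsewhere on the ring would give a similar number.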